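Moving the ethoxy group across the outer ring

The source may hold more compounds than are shown below. What is called first, only, known or untested is meant among the compounds shown, and "the series" means these compounds.

Compound 3 `CCOc1ccccc1-c1ccc(C(=O)NC(/C=C/c2ccccc2)C(Cc2cccc(C(=N)N)c2)C(=O)OC)cc1` gives 1800 nM in an assay on isolated protein (Oryctolagus cuniculus) for inhibition of Trypsin (Homo sapiens) (on this read-out lower numbers stand for stronger inhibition and higher numbers for weaker inhibition), the lowest of the three numbers recorded, yet its steps to the others stay within the scatter: compound 1 `COC(=O)C(Cc1cccc(C(=N)N)c1)C(/C=C/c1ccccc1)NC(=O)c1ccc(-c2ccc(C)cc2)cc1` gives 2800 nM and compound 2 `COC(=O)C(Cc1cccc(C(=N)N)c1)C(/C=C/c1ccccc1)NC(=O)c1ccc(-c2ccc(OC)cc2)cc1` gives 2900 nM. Compound 4 `CCOc1ccc(-c2ccc(C(=O)NC(/C=C/c3ccccc3)C(Cc3cccc(C(=N)N)c3)C(=O)OC)cc2)cc1` differs from compound 3 by 4-ethoxyphenyl in place of 2-ethoxyphenyl on an aromatic carbon. Within the data shown here, three measured steps bear on this change. Among them, a 1.6-fold lower number from compound 2 to compound 3 (0.21 log units; within the scatter) is the closest in kind, since it exchanges one ring substituent pattern for the other, and a 1.6-fold lower number from compound 1 to compound 3 (0.19 log units; within the scatter) points the same way; a 1.0-fold higher number from compound 1 to compound 2 (0.02 log units; within the scatter) shows that swapping the group on the outer ring changed little. All three steps fall inside the scatter, so no movement beyond it is expected from the change to compound 4. Compound 4 is therefore estimated at 2600 nM, with a range of 1200 nM to 5500 nM. This estimate corresponds to an expected step of a 1.4-fold higher number from compound 3 to compound 4 (0.16 log units; within the scatter).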

Compound 4, half-maximal inhibitory concentration: 2800 nM
The estimate for compound 4 lay 1.1-fold (0.03 log units) below the measured number, and the stated range covers the measured number.
By their numbers in this assay, from the lowest: compounds 3, 1, 4 and 2 (each within the scatter of the next).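

Moving the ethoxy group around the outer ring, with the same atoms joined differently, gives a 1.6-fold higher number from compound 3 to compound 4 (0.19 log units; within the scatter) in this assay, so changing where this group sits on the ring, which the earlier compounds did not test on its own, produced no movement beyond the scatter. Changing the size of the group at the para place also produced none: adding methyl to the methoxy group gives a 1.0-fold lower number from compound 2 to compound 4 (0.02 log units; within the scatter), and ethoxy in place of methyl gives no change at the digits printed from compound 1 to compound 4 (within the scatter), so all four compounds remain within the scatter of their neighbours in the order. From the compounds shown here alone, whether a different group on the outer ring, such as an amine, a carboxylic acid or a longer chain, would move the number beyond the scatter stays open. No measurement shown offers a reason for how closely these compounds agree.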